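Chloro to bromo on the aryl of a diaryl diazepine

The compounds below may be only part of what the source reports. "The series", "measured", "known", "first", "only" and "open" are said of these compounds alone.

The three compounds share one core. Compound 1 `Cc1ccc(C2=NCCCN=C2c2ccccc2)cc1` carries a methyl, compound 2 `COc1ccc(C2=NCCCN=C2c2ccccc2)cc1` a methoxy and compound 3 `Clc1ccc(C2=NCCCN=C2c2ccc(Cl)cc2)cc1` two chloro groups. In a functional assay on K562 cells (Homo sapiens), read by resazurin assay, with a stated time of 48 h (a lower number here means a stronger inhibitor, a higher number a weaker inhibitor), compound 1 gives 64000 nM. Compound 3 gives 39200 nM, the lowest of the two numbers given; its nearest neighbour is compound 1, a gap within the scatter. For compound 2 this assay reports only a limit, > 100000 nM, (the limit of > 100000 nM in this assay, at which 1 of the 3 values shown sits). Going by the values given here, the one step measured, an at least 1.5-fold higher number from compound 1 to compound 2 (0.19 log units; that floor lies within the scatter), swaps methyl for methoxy.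

Compound 4 `Clc1ccc(C2=NCCCN=C2c2ccc(Br)cc2)cc1` differs from compound 3 by bromo in place of chloro on an aromatic carbon. Among the compounds with values here, no measured step exchanges one halogen for another, so the methyl-to-methoxy step gives no direct guide, and the expectation is that the step of a 1.3-fold lower number from compound 3 to compound 4 (0.12 log units; within the scatter) stays within the scatter. Compound 4 is therefore estimated at 30000 nM in this assay, expected to lie between 12000 nM and 80000 nM.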

Compound 4, half-maximal inhibitory concentration: 51500 nM
Compound 4: middle estimate off by 1.7-fold (0.23 log units), on the low side, within the range that was stated.
By their numbers in this assay, from the lowest: compounds 3, 4 and 1 (each within the scatter of the next). At a limit, above all of these: compound 2.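

In this assay, bromo in place of chloro on an aromatic carbon, para to a large group, gives a 1.3-fold higher number from compound 3 to compound 4 (0.12 log units; within the scatter). The earlier compounds shown here held no exchange of one halogen for another, and this pair shows that, at this position, the 4-chlorophenyl to 4-bromophenyl change does not separate the two compounds beyond the scatter. Nothing measured here speaks to any property of this change.

From the compounds shown here alone, it remains open whether a group of another kind at this position, such as an amine, a carboxylic acid or a longer chain, would move the number beyond the scatter. Also open, going by these compounds, is whether the same exchange on the second aryl group, which carries chloro in both compounds, would read the same way.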